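Amide-to-urea step on the pyrazole series

The source may report more compounds than this note shows. Statements on the series, on what has been measured and on what is new or still open speak of the compounds shown alone.

Of the compounds shown here, two have numbers so far. Compound 1 `COc1cc(-c2nn(-c3cccc(NC(=O)c4cccc(C(F)(F)F)c4)c3)cc2-c2ccncc2)ccc1Cl` gives 710 nM in a functional assay on MDA-MB-435 cells (Homo sapiens) for inhibition, read by sulforhodamine B assay, with a stated time of 48 h; a higher number here means a weaker inhibitor, a lower number a stronger inhibitor. Compound 2 `O=C(Nc1cccc(-n2cc(-c3ccncc3)c(-c3ccc(Cl)c(O)c3)n2)c1)Nc1cc(C(F)(F)F)cc(C(F)(F)F)c1` gives 910 nM in this assay; its value and that of compound 1 lie within the scatter of each other, so neither stands apart. Compound 3 `COc1cc(-c2nn(-c3cccc(NC(=O)Nc4ccc(Cl)c(C(F)(F)F)c4)c3)cc2-c2ccncc2)ccc1Cl` carries (4-chloro-3-(trifluoromethyl)phenyl)amino in place of 3-(trifluoromethyl)phenyl on a carbonyl carbon. Compound 3 is expected to give 600 nM in this assay, with a range of 250 nM to 1500 nM, because compound 2 at 910 nM shows a related urea at a similar level. The expected step of a 1.2-fold lower number from compound 1 to compound 3 (0.07 log units; within the scatter) is thus small and within the scatter.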

Compound 3, half-maximal inhibitory concentration: 680 nM
Compound 3: the middle estimate sits 1.1-fold (0.05 log units) below what was measured, and the stated range covers the measured number.
By their numbers in this assay, from the lowest: compounds 3, 1 and 2 (each within the scatter of the next).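

In this assay, (4-chloro-3-(trifluoromethyl)phenyl)amino in place of 3-(trifluoromethyl)phenyl on a carbonyl carbon gives a 1.0-fold lower number from compound 1 to compound 3 (0.02 log units; within the scatter) and so stays within the scatter. This first one-place comparison shows that this position takes the change, with its added chlorine and hydrogen-bond donor, without a readable shift in the number. No supporting data bear on this result. The amino link and the chlorine enter together, so their separate contributions remain unresolved. From the compounds shown here alone, whether an aliphatic amine or a carboxylic acid at this carbonyl carbon would shift the number also remains open.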